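A few compounds are considered here, and "the series" means these few. Any claim that something is new, unique, unknown or untested is made for them only; others in the source may bear on it.

Working notes on the series. Compound 1 `COC(=O)c1sc2cc(C#Cc3ccccn3)cnc2c1N` gives 13900 nM in a functional assay on A375-C5 cells (Homo sapiens) for inhibition, read by sulforhodamine B assay, with a stated time of 48 h; a higher number here means a weaker inhibitor of growth, a lower number a stronger inhibitor of growth. Compound 2 `COC(=O)c1sc2cc(C#Cc3ccc(N)cc3)cnc2c1N` gives 4800 nM in this assay. Compound 3 `COC(=O)c1sc2cc(C#Cc3cccnc3)cnc2c1N` returns only > 150000 nM in this assay, which is a limit of the assay and not a number. Compound 3 therefore stands at the weak end of the three values shown; both steps into it, an at least 10-fold higher number from compound 1 to compound 3 (1.03 log units; beyond the scatter) and an at least 31-fold higher number from compound 2 to compound 3 (1.49 log units; beyond the scatter), are large and run toward a higher number, whereas a 2.9-fold lower number from compound 1 to compound 2 (0.46 log units; beyond the scatter) is modest. Compound 4 `COC(=O)c1sc2cc(C#Cc3ccc(F)cc3)cnc2c1N` is not yet measured. It differs from compound 3 in one place: 4-fluorophenyl in place of pyridin-3-yl on a triple-bonded carbon. For the measured compounds named here, the steps that bear on this change are the two that arrive at pyridin-3-yl on the triple-bonded carbon; read in reverse they show that exchanging pyridin-3-yl for either pyridin-2-yl or 4-aminophenyl lowers the number by a large amount. Compound 4 carries a six-membered aromatic ring of carbon only, as compound 2 does. Since compound 3 sits at the limit of > 150000 nM in this assay, at which 1 of the 3 values shown sits, the true size of any step from it is itself only bounded. For compound 4 a large drop, an at least 15-fold lower number from compound 3 to compound 4 (1.17 log units; beyond the scatter), is expected. The estimated value for compound 4 is 10000 nM, with a range from 3000 nM to 60000 nM.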

Compound 4, concentration for 50% growth inhibition: 48400 nM
Compound 4: middle estimate off by 4.8-fold (0.68 log units), on the low side; the measured number falls inside the stated range.
By their numbers in this assay, from the lowest: compound 2; then compound 1; then compound 4. At a limit, above all of these: compound 3.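

In the notes that follow, compound 3 is held at a limit of the assay and not at a number, which leaves any step out of it bounded on one side only: the limit of > 150000 nM in this assay, at which 1 of the 4 values shown sits. Even so, 4-fluorophenyl in place of pyridin-3-yl on a triple-bonded carbon gives an at least 3.0-fold lower number from compound 3 to compound 4 (0.49 log units; beyond the scatter) in this assay and brings this position back to a measured number, though not to the level of the other two compounds. A ring of carbon only is not sufficient for that level, since the group on the ring also counts: fluoro in place of amino on an aromatic carbon gives a 10-fold higher number from compound 2 to compound 4 (1.00 log units; beyond the scatter) and, against any simple preference for carbon-only rings, 4-fluorophenyl in place of pyridin-2-yl gives a 3.5-fold higher number from compound 1 to compound 4 (0.54 log units; beyond the scatter) in the same assay.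

Open, from the compounds shown here alone, is where a hydroxyl, a methoxy or a dimethylamino group on that aromatic carbon would fall relative to compound 2 and compound 4. Also open, going by these compounds, is whether the same order holds when the methyl ester of the shared core gives way to a carboxylic acid or an amide.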